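The source may report more compounds than this note shows. Statements on the series, on what has been measured and on what is new or still open speak of the compounds shown alone.

For the measured compounds named here, in an assay on CHO-K1 cells for antagonist activity at adenosine receptor A1 (Homo sapiens), read by a beta-galactosidase reporter, with stated times of 15 min and 6 h (a higher number here means a weaker inhibitor, a lower number a stronger inhibitor), compound 2 `N#Cc1ccc(-c2nc(N)c3cc(CN4CC=CCC4)sc3n2)cc1` gives 1630 nM, the lowest of the two numbers measured so far, while compound 1 `Nc1nc(-c2cocn2)nc2sc(CN3CC=CC3)cc12` gives 3900 nM, a gap that lies beyond the usual scatter. Compound 3 `N#Cc1ccc(-c2nc(N)c3cc(CN4CC=CC4)sc3n2)cc1` differs from compound 2 in a single place: a group of 5 heavy atoms (4 carbon, 1 nitrogen; one five-membered non-aromatic ring with 1 hetero atom) in place of a group of 6 heavy atoms (5 carbon, 1 nitrogen; one six-membered non-aromatic ring with 1 hetero atom), on a saturated chain carbon bound to an aromatic carbon. Going by the values given here, no pair of measured compounds shows this exact change, so in this assay the step is expected to be small, in no firm direction, and quite possibly not beyond the scatter. The expected step is a 1.1-fold lower number from compound 2 to compound 3 (0.04 log units; within the scatter). Compound 3 is therefore estimated at 1500 nM, within a range from 500 nM to 4500 nM.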

Compound 3, inhibition constant: 2350 nM
The estimate for compound 3 lay 1.6-fold (0.19 log units) below the measured number; measured number inside the range.
By their numbers in this assay, from the lowest: compounds 2, 3 and 1 (each within the scatter of the next, the first and the last beyond it).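

In this assay, the five-membered ring in place of the six-membered ring, on a saturated chain carbon bound to an aromatic carbon, gives a 1.4-fold higher number from compound 2 to compound 3 (0.16 log units; within the scatter) and so leaves these two rings unseparated at this position. With the five-membered ring kept, 4-cyanophenyl in place of 1,3-oxazol-4-yl on an aromatic carbon gives a 1.7-fold lower number from compound 1 to compound 3 (0.22 log units; within the scatter) and is likewise unresolved. No measurement shown offers an explanation for these results. Open, from the compounds shown here alone, is whether an open-chain amine such as diethylamine or a saturated ring such as morpholine at this position would shift the number beyond the scatter.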